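Cyclopentyl for furanylmethyl on the acylsemicarbazide nitrogen

The source may report more compounds than this note shows. Statements on the series, on what has been measured and on what is new or still open speak of the compounds shown alone.

Measured compounds:
compound 1 `Cn1cc([N+](=O)[O-])cc1C(=O)NNC(=O)NCc1ccco1`: 482000 nM
compound 2 `O=C(NCc1ccco1)NNC(=O)c1cc([N+](=O)[O-])c[nH]1`: 443000 nM
compound 3 `O=C(NNC(=S)Nc1ccc(Cl)cc1)c1cc([N+](=O)[O-])c[nH]1`: 191000 nM

All three were read in an ADME assay on Vero cells (Chlorocebus sabaeus) for cytotoxicity, read by MTT assay, with a stated time of 72 h; a lower number here means a stronger inhibitor, a higher number a weaker inhibitor. Among the measured compounds shown here, compound 1 and compound 2 lie within the scatter of each other, the only single-point step so far being a 1.1-fold lower number from compound 1 to compound 2 (0.04 log units; within the scatter). For the measured compounds named here, compound 3 gives a lower number than compound 1, and no single-point step connects the two.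

Compound 4 `Cn1cc([N+](=O)[O-])cc1C(=O)NNC(=O)NC1CCCC1` is the next compound, not yet measured. It differs from compound 1 by cyclopentyl in place of (furan-2-yl)methyl on an amide-type nitrogen. Going by the values given here, no measured pair shows this change or anything like it on the amide-type nitrogen; the one known step changes a methyl on an aromatic nitrogen and is within the scatter. There is thus no basis for expecting movement in this assay beyond the scatter in either direction.

Compound 4 is therefore expected to give about 450000 nM, with a range from 200000 nM to 1000000 nM, the estimated step being a 1.1-fold lower number from compound 1 to compound 4 (0.03 log units; within the scatter).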

Compound 4, half-maximal inhibitory concentration: 271000 nM
Compound 4: the middle estimate sits 1.7-fold (0.22 log units) above what was measured; measured number inside the range.
By their numbers in this assay, from the lowest: compounds 3, 4, 2 and 1 (each within the scatter of the next, the first and the last beyond it).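

The amide-type nitrogen now has its first single-point reading in this assay: cyclopentyl in place of (furan-2-yl)methyl gives a 1.8-fold lower number from compound 1 to compound 4 (0.25 log units; within the scatter). Exchanging a five-membered aromatic ring with one hetero atom for a five-membered non-aromatic ring of carbon only therefore does not carry the number beyond the scatter, and this step joins the earlier one on the aromatic nitrogen in staying inside it. No measurement on hand bears on why these two groups read alike.

A single pair cannot show how far this nitrogen can be changed before the number moves beyond the scatter. From the compounds shown here alone, it remains open whether a longer alkyl chain, a benzyl group or a chain ending in a carboxylic acid would read like cyclopentyl in this assay.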